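This account rests on a few compounds, and the source may have more. Where it says the series, first, only, none or still open, it means among the compounds named here.

Compound 1 `Cc1cc(C(=O)O)ccc1OCCCCOc1ccc(C(=O)CC(C)C)c(O)c1C`: 41%
Compound 2 `COc1cc(C(=O)O)ccc1OCCCCOc1ccc(C(=O)CC(C)C)c(O)c1C`: 43%
Compound 3 `Cc1c(OCCCCOc2cccc(C(=O)O)c2)ccc(C(=O)CC(C)C)c1C`: 29%

In an ADME assay (liver) for metabolic stability, with Liver microsome (Rattus norvegicus) as the target, read by LC-MS, using microsomes and NADPH, with stated times of 5 min and 60 min, tested at 4 uM (on this read-out lower numbers stand for a less stable compound and higher numbers for a more stable compound), compound 1 sits within the scatter of compound 2 at the upper end of these three numbers, and compound 3 lies below it, beyond the scatter. Compound 4 `Cc1ccc(C(=O)O)cc1OCCCCOc1ccc(C(=O)CC(C)C)c(O)c1C` has the same atoms as compound 1, joined differently, with 5-carboxy-2-methylphenyl in place of 4-carboxy-2-methylphenyl on an oxygen on a saturated carbon. Going by the values given here, no measured step tests this change directly. Among the compounds with values here, the one single-place step available (a number 2 percentage points higher from compound 1 to compound 2 (within the scatter)) stayed within the scatter. Within the data shown here, compound 3 differs from compound 1 in more than one place and offers no single step. No step beyond the scatter is therefore expected in this assay and no direction can be favoured. The estimated step (a number 1 percentage points lower from compound 1 to compound 4 (within the scatter)) is accordingly small. For compound 4 the estimated value is 40% with an expected range from 28% to 52% in this read-out.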

Compound 4, percent of the compound remaining: 21%
Beside the measured number, compound 4's estimate is 19 percentage points above it; the whole stated range lies above it.
By their numbers in this assay, from the lowest: compounds 4 and 3 (each within the scatter of the next); then compounds 1 and 2 (each within the scatter of the next).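

In this assay, the exchange of 4-carboxy-2-methylphenyl for 5-carboxy-2-methylphenyl on an oxygen on a saturated carbon gave a number 20 percentage points lower from compound 1 to compound 4 (beyond the scatter). Going by these compounds alone, this is the first single-place step here to pass the scatter: the earlier one, methoxy in place of methyl, gave a number 2 percentage points higher from compound 1 to compound 2 (within the scatter), whereas in this change the two groups have the same atoms, joined differently, so at this place the joining alone is enough to move the number. Nothing shown here gives a reason for this step.

Going by these compounds, whether methoxy in place of methyl would leave compound 4 as unmoved as it left compound 1 remains open. So does the outcome of a primary amide or a tetrazole in place of the carboxylic acid on 5-carboxy-2-methylphenyl.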